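The source may hold more compounds than are shown below. What is called first, only, known or untested is meant among the compounds shown, and "the series" means these compounds.

Of the compounds shown here, three that share one core have been tested in an ADME assay on MCF-10A cells (Homo sapiens) for inhibition, with a stated time of 48 h (on this read-out higher numbers stand for weaker inhibition and lower numbers for stronger inhibition), and all three stop at the same boundary. Compound 1 `O=C(Nc1ccc(Cl)cc1)N1CCC[C@H]1c1nc(-c2ccccc2Cl)no1` gives in this assay a value of > 50000 nM, which is a limit of the assay and not a number. Compound 2 `O=C(Nc1ccc(Cl)cc1)N1CCC[C@H]1c1nc(-c2ccccc2Br)no1` likewise gives in this assay a value of > 50000 nM, again a limit. Compound 3 `O=C(Nc1ccc(Cl)cc1)N1CCC[C@H]1c1nc(-c2cccc(Cl)c2)no1` also reaches in this assay only a limit, > 50000 nM. The change from compound 1 to compound 2 is bromo in place of chloro on an aromatic carbon, and its step in this assay is a step that the two limits leave unreadable from compound 1 to compound 2 because of the limit of > 50000 nM in this assay, at which 3 of the 3 values shown sit. The cores of compound 1 and compound 3 differ as 3-chlorophenyl in place of 2-chlorophenyl on an aromatic carbon, and the step that the two limits leave unreadable from compound 1 to compound 3 is equally unreadable, as is a step that the two limits leave unreadable from compound 2 to compound 3.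

Compound 4 `O=C(Nc1ccc(Cl)cc1)N1CCC[C@H]1c1nc(-c2cccc(Br)c2)no1` is not yet measured. Its change from compound 3 is bromo in place of chloro on an aromatic carbon, the same kind of change as that from compound 1 to compound 2, but at a place that is meta to a large group rather than ortho to a large group. Since compound 3 sits at > 50000 nM and the earlier step gave no readable size, compound 4 is expected to remain at the limit, an estimated step that the limit leaves unreadable from compound 3 to compound 4 and an estimated value of 60000 nM.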

Compound 4, half-maximal inhibitory concentration: > 50000 nM
Compound 4: no number, only a limit (the forecaster's own chance of this, stated with the estimate: 85%); the middle value lies beyond the limit too.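

No step from compound 1, compound 2 or compound 3 to compound 4 can be read in this assay, because all four compounds stop at the same boundary: the limit of > 50000 nM in this assay, at which 4 of the 4 values shown sit.

The compounds shown leave open how strongly any of them inhibits, and whether bromo in place of chloro, or 3-chlorophenyl in place of 2-chlorophenyl, changes that at all.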